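A Methyl for a Fluoro on the Shared Core

The compounds below may be only part of what the source reports. "The series", "measured", "known", "first", "only" and "open" are said of these compounds alone.

Compound 1 `C(=N/c1ccccc1)\c1cc(-c2ccccc2)no1` and compound 2 `Fc1ccc(-c2cc(/C=N/c3ccccc3)on2)cc1` share one core and differ by a single fluorine. In a functional assay on A549 cells (Homo sapiens) for inhibition, read by MTT assay, with a stated time of 24 h (a higher number here means a weaker inhibitor, a lower number a stronger inhibitor), compound 1 gives 48100 nM, and in this assay compound 2 gives 34500 nM. The step of a 1.4-fold lower number from compound 1 to compound 2 (0.14 log units; within the scatter) lies within the scatter, so compound 2 stands alongside compound 1 rather than apart from it. Compound 3 `Cc1ccc(-c2cc(/C=N/c3ccccc3)on2)cc1` carries methyl in place of fluoro on an aromatic carbon. Going by the values given here, only the step from compound 1 to compound 2 bears on this change, and it was small, so no shift beyond the scatter is expected in this assay. Compound 3 is therefore estimated at 32000 nM, with a range from 12000 nM to 85000 nM, meaning an expected step of a 1.1-fold lower number from compound 2 to compound 3 (0.03 log units; within the scatter).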

Compound 3, half-maximal inhibitory concentration: 32000 nM
Estimate against measurement, compound 3: no gap at the digits printed; measured number inside the range.
By their numbers in this assay, from the lowest: compounds 3, 2 and 1 (each within the scatter of the next).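

At this place on the ring, para to a large group, a 1.1-fold lower number from compound 2 to compound 3 (0.03 log units; within the scatter) and a 1.5-fold lower number from compound 1 to compound 3 (0.18 log units; within the scatter) both hold in this assay as the short name for the test. So methyl, like fluoro, does not set its compound apart, and hydrogen, fluoro and methyl all read alike here. Going by these compounds, whether an amine, a carboxylic acid or a longer chain at this place would move the number beyond the scatter stays open. Nothing at hand gives a reason for this flat result.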